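The Same Aryl Swap Tried on a Second Core

This account rests on a few compounds, and the source may have more. Where it says the series, first, only, none or still open, it means among the compounds named here.

Three compounds have been measured in an ADME assay on HeLa cells (Homo sapiens) for cytotoxicity, read by cell counting, with a stated time of 4 days; a higher number here means a weaker inhibitor, a lower number a stronger inhibitor:

Compound 1 `O=c1[nH]c(=O)n([C@H]2C[C@H](O)[C@@H](CO)O2)cc1-c1cn(-c2c(F)cccc2F)nn1`: 510 nM
Compound 2 `CC(C)c1ccc(-n2cc(-c3cn([C@H]4C[C@H](O)[C@@H](CO)O4)c(=O)[nH]c3=O)nn2)cc1`: 6200 nM
Compound 3 `O=c1[nH]c(=O)n([C@H]2C[C@H](O)[C@@H](CO)O2)cc1-c1cnnn1-c1c(F)cccc1F`: 5000 nM

Compound 1 and compound 2 differ in one place, (4-isopropylphenyl in place of 2,6-difluorophenyl on an aromatic nitrogen), and the number changes by a 12-fold higher number from compound 1 to compound 2 (1.08 log units; beyond the scatter). Compound 3 is built from the same atoms as compound 1, joined differently; the difference between the two cores is not broken down here. Compound 3 and compound 2 give numbers within the usual scatter of each other.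

Compound 4 `CC(C)c1ccc(-n2nncc2-c2cn([C@H]3C[C@H](O)[C@@H](CO)O3)c(=O)[nH]c2=O)cc1` is not yet measured. It differs from compound 3 by 4-isopropylphenyl in place of 2,6-difluorophenyl on an aromatic nitrogen, the same kind of change as from compound 1 to compound 2, though not the same: here the group sits next to the ring atom that bears a large group, whereas before it sat two ring bonds from that atom. Resting on the value of compound 3, 5000 nM, and on a 12-fold higher number from compound 1 to compound 2 (1.08 log units; beyond the scatter), a step of a 5.0-fold higher number from compound 3 to compound 4 (0.70 log units; beyond the scatter) is expected in this assay; the different surroundings of the change leave this less certain. Compound 4 is estimated at 25000 nM, expected to lie between 7000 nM and 90000 nM.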

Compound 4, half-maximal inhibitory concentration: > 200000 nM
Compound 4: only a limit was reported; the forecaster's own chance of this, stated with the estimate: 25%; middle value at least 8.0-fold (0.90 log units) away from the limit.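

In this assay compound 4 gives > 200000 nM, which is a limit of the assay and not a number. Putting 4-isopropylphenyl in place of 2,6-difluorophenyl raises the number on both cores, here with an at least 40-fold higher number from compound 3 to compound 4 (1.60 log units; beyond the scatter), but the size of the step does not carry over from one core to the other: the same change on two cores in this assay, a 12-fold higher number (1.08 log units; beyond the scatter) from compound 1 to compound 2 and an at least 40-fold higher number (1.60 log units; beyond the scatter) from compound 3 to compound 4, at least 3.2-fold (0.51 log units) apart, beyond the scatter of two such steps. Going by these compounds, how large the step on the core of compound 3 really is stays open, and two cores set no general rule: the limit of > 200000 nM in this assay, at which 1 of the 4 values shown sits.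

The compounds shown leave open whether the two cores would also part ways with an unsubstituted phenyl or a cyclohexyl on that nitrogen. They also leave open which part of either aryl group matters, since each group changes as a whole.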